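From Methylsulfonyl to Phenylsulfanyl on the Side Chain

This account rests on a few compounds, and the source may have more. Where it says the series, first, only, none or still open, it means among the compounds named here.

In a functional assay on the whole organism with Rattus norvegicus as the target (a lower number here means that less compound is needed, a higher number that more compound is needed for the effect), compound 3 `CS(=O)(=O)CCn1c(=N)sc2cc(OC(F)(F)F)ccc21` gives 1.8 mg/kg and compound 2 `C[S+]([O-])Cn1c(=N)sc2cc(OC(F)(F)F)ccc21` gives 2.3 mg/kg, two values within the scatter of each other. Compound 1 `COC(=O)Cn1c(=N)sc2cc(OC(F)(F)F)ccc21` gives > 10 mg/kg, which is a limit and not a number. Compound 4 `N=c1sc2cc(OC(F)(F)F)ccc2n1CCSc1ccccc1` carries phenylsulfanyl in place of methylsulfonyl on a saturated chain carbon, two bonds along the chain from an aromatic nitrogen. For the measured compounds named here, no measured step makes this exact swap. The nearest guides are a 1.3-fold lower number from compound 2 to compound 3 (0.11 log units; within the scatter) and the larger at least 5.5-fold lower number from compound 1 to compound 3 (0.74 log units; beyond the scatter), so side chain changes here can matter or do almost nothing. A modest rise is expected, namely a 1.7-fold higher number from compound 3 to compound 4 (0.22 log units; within the scatter). For compound 4, the estimated value in this assay is 3 mg/kg, with a range from 1 mg/kg to 10 mg/kg.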

Compound 4, dose for half-maximal effect: 4.5 mg/kg
Compound 4: middle estimate off by 1.5-fold (0.18 log units), on the low side; the range from low to high includes it.
By their numbers in this assay, from the lowest: compounds 3, 2 and 4 (each within the scatter of the next, the first and the last beyond it). At a limit, above all of these: compound 1.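

In this assay, the first side chain here with an aromatic ring gives a 2.5-fold higher number from compound 3 to compound 4 (0.40 log units; beyond the scatter), so this position tolerates phenylsulfanyl at a modest cost. Set against the shorter sulfur side chain, the gap is a 2.0-fold higher number from compound 2 to compound 4 (0.29 log units; within the scatter). A bound and not a number comes from an at least 2.2-fold lower number from compound 1 to compound 4 (0.34 log units; beyond the scatter), which rests on a limit: the limit of > 10 mg/kg in this assay, at which 1 of the 4 values shown sits.

As far as these compounds go, the ring and the oxygens on sulfur change together in the step from methylsulfonyl, so their separate shares stay open, and phenylsulfonyl would pull them apart. From the compounds shown here alone, how an amine or a carboxylic acid on this chain would behave also remains open.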